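The compounds below may be only part of what the source reports. "The series", "measured", "known", "first", "only" and "open" are said of these compounds alone.

Measured compounds in the series:
compound 1, `CCCCCCCCCCCCOc1ncnc2c1ncn2CC(=O)OCC`: > 10 ug/mL in an ADME assay on Vero cells (Chlorocebus sabaeus) for cytotoxicity; on this read-out higher numbers stand for lower toxicity in this test and lower numbers for higher toxicity in this test
compound 2, `CCCCCCCCCCCCOc1ncnc2[nH]cnc12`: "not determined" (no result reported) in this assay

Compound 1 gives > 10 ug/mL in this assay, which is a limit of the assay and not a number. Within the data shown here, for compound 2 no single number stands on this read-out; the only further value shown is the limit of > 10 ug/mL in this assay, at which 1 of the 2 values shown sits, so compound 2 has no measured place of its own here, and nothing can be said of its standing relative to compound 1 beyond that one value being a limit.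

Compound 3, `CCCCCCCCCCCCOc1nc(N)nc2[nH]cnc12`, differs from compound 2 by amino in place of hydrogen on an aromatic carbon.

Among the measured compounds shown here, no step between measured compounds exists in this assay, so no size or direction of step can be drawn from the data for the move from compound 2 to compound 3. For the measured compounds named here, with only one value shown, and that a limit, the expectation is that the change produces nothing beyond the scatter in this assay, with a fair chance that the read-out is again reported only as a limit.

Compound 3 is estimated at 15 ug/mL in this assay, with an expected range from 5 ug/mL to 50 ug/mL.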

Compound 3, half-maximal cytotoxic concentration: > 10 ug/mL
Compound 3: only a limit was reported (the forecaster's own chance of this, stated with the estimate: 65%); the middle value does not contradict the limit.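

In this assay compound 3 gives > 10 ug/mL, which is a limit of the assay and not a number. Among these compounds, with compound 2 at "not determined" (no result reported), no step from compound 2 to compound 3 can be read. Still open, as far as these compounds go, is whether amino in place of hydrogen on the aromatic carbon changes the read-out in this assay at all.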